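A few compounds are considered here, and "the series" means these few. Any claim that something is new, unique, unknown or untested is made for them only; others in the source may bear on it.

Measured so far in an ADME assay on NIH3T3 cells (Homo sapiens) for cytotoxicity, read by sulforhodamine B assay, with a stated time of 48 h; a higher number here means a weaker inhibitor, a lower number a stronger inhibitor:
compound 1 `COc1ccc2c(c1)c(C=O)cn2Cc1cn([C@@H]2O[C@H](COC(C)=O)[C@@H](OC(C)=O)[C@H](OC(C)=O)[C@H]2OC(C)=O)nn1` — > 200000 nM, a limit of the assay.
compound 2 `CC(=O)OC[C@H]1O[C@@H](n2cc(Cn3cc([N+](=O)[O-])c4ccccc43)nn2)[C@H](OC(C)=O)[C@@H](OC(C)=O)[C@@H]1OC(C)=O` — 20500 nM.
compound 3 `CC(=O)OC[C@H]1O[C@@H](n2cc(Cn3cc(/C=C/C(=O)c4cccnc4)c4ccccc43)nn2)[C@H](OC(C)=O)[C@@H](OC(C)=O)[C@@H]1OC(C)=O` — > 200000 nM, a limit of the assay.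

Compound 3 thus stands at the limit that holds two of the three values, as recorded in the limit of > 200000 nM in this assay, at which 2 of the 3 values shown sit; compound 2 alone gives a number. Compound 4 `CC(=O)OC[C@H]1O[C@@H](n2cc(Cn3cc(/C=C4/C(=O)Nc5ccc(F)cc54)c4ccccc43)nn2)[C@H](OC(C)=O)[C@@H](OC(C)=O)[C@@H]1OC(C)=O` differs from compound 3 by a group of 12 heavy atoms (9 carbon, 1 nitrogen, 1 oxygen, 1 fluorine; one five-membered non-aromatic ring with 1 hetero atom, one six-membered aromatic ring of carbon only) in place of a group of 10 heavy atoms (8 carbon, 1 nitrogen, 1 oxygen; one six-membered aromatic ring with 1 hetero atom), on an aromatic carbon. Going by the values given here, the only measured step bearing on this position, an at least 9.7-fold higher number from compound 2 to compound 3 (0.98 log units; beyond the scatter), ran from a number up to the limit; no step between two numbers exists. The change to compound 4 again leaves a large substituent at that position, so no step beyond the scatter is expected, a number no higher from compound 3 to compound 4 (the limit leaves the size open). The result for compound 4 is expected most likely to be another limit. Compound 4 is estimated at 200000 nM, within 50000 nM to 400000 nM.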

Compound 4, half-maximal inhibitory concentration: 62500 nM
For compound 4 the middle estimate is 3.2-fold (0.51 log units) above the measured one, and the stated range covers the measured number.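

In this assay the change at this aromatic carbon gives an at least 3.2-fold lower number from compound 3 to compound 4 (0.50 log units; beyond the scatter), and a large group here does not by itself hold the value at the limit. The nitro group still gives the lower number, with a 3.0-fold higher number from compound 2 to compound 4 (0.48 log units; beyond the scatter). Compound 3 remains a limit and not a number: the limit of > 200000 nM in this assay, at which 2 of the 4 values shown sit.

The compounds shown leave open which part of the entering group carries the step: the fluorine, the amide hydrogen or the five-membered ring. Going by these compounds, how an amine or a carboxylic acid would read at this position also stays open.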